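The source may report more compounds than this note shows. Statements on the series, on what has been measured and on what is new or still open speak of the compounds shown alone.

Compound 1, `CCOC(=O)C1=C(C)NC(=S)NC1C1CCCCC1`: 25.2 ug/mL
Compound 2, `CCOC(=O)C1=C(C)NC(=S)NC1c1cccc(OC)c1`: 28.3 ug/mL
Compound 3, `CCOC(=O)C1=C(C)NC(=S)NC1c1ccc(F)cc1`: 26.5 ug/mL

All three numbers come from a functional assay on HT-29 cells (Homo sapiens) for inhibition, read by sulforhodamine B assay, with a stated time of 48 h; a lower number here means a stronger inhibitor of growth, a higher number a weaker inhibitor of growth. Compound 3 sits in the middle of the three, but none of the gaps carries weight: its number lies nearest to that of compound 1 and furthest from that of compound 2, and both gaps stay within the usual scatter of repeated measurements. In other words, the three compounds, which share one core and differ only in the group attached to it, cannot be told apart on these numbers.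

Compound 4, `CCOC(=O)C1=C(C)NC(=S)NC1c1ccc(SC)cc1`, has not yet been measured. It differs from compound 3 in one place: methylsulfanyl in place of fluoro on an aromatic carbon. Going by the values given here, no step between two measured compounds isolates this kind of swap, so there is no direct guide to its size. What the measured compounds do show is that three rather different groups at this point of the core all land on much the same number. On that basis the step is expected to stay within the scatter: a 1.1-fold lower number from compound 3 to compound 4 (0.04 log units; within the scatter). Compound 4 is therefore estimated at 24 ug/mL in this assay, with a range from 12 ug/mL to 48 ug/mL.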

Compound 4, concentration for 50% growth inhibition: 17.2 ug/mL
The estimate for compound 4 lay 1.4-fold (0.14 log units) above the measured number; measured number inside the range.
By their numbers in this assay, from the lowest: compounds 4, 1, 3 and 2 (each within the scatter of the next).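

In this assay, going by these compounds alone, the swap of fluoro for methylsulfanyl on an aromatic carbon, para to a large group, gives the first step that isolates a single change at this place (a 1.5-fold lower number from compound 3 to compound 4 (0.19 log units; within the scatter)). Even with a larger group containing sulfur in place of a single fluorine, the change cannot be told apart from repeat-measurement noise, so this place on the ring tolerates both groups with no clear effect on growth inhibition. Nothing measured here bears on why the two groups give such similar numbers.

The compounds shown leave open whether an amine, a carboxylic acid or a longer chain at the same place would also leave the number unmoved. They also leave open whether a change elsewhere on the shared core, such as replacing the ethyl ester, would produce a step beyond the scatter.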